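A Halogen-Bearing Aryl Swap on the Sulfur Linker

The source may hold more compounds than are shown below. What is called first, only, known or untested is meant among the compounds shown, and "the series" means these compounds.

Of the compounds shown here, three sharing a common core have been tested in a functional assay on HCT-116 cells (Homo sapiens) for antiproliferative activity, read by MTT assay, with a stated time of 72 h; a higher number here means a weaker inhibitor, a lower number a stronger inhibitor. Compound 1 `O=C(CSc1ncc[nH]1)Nc1ccc2nc(NC(=O)c3ccc(C(F)(F)F)cc3)sc2c1` gives 2690 nM. Compound 2 `O=C(CSc1ccc2ccccc2c1)Nc1ccc2nc(NC(=O)c3ccc(C(F)(F)F)cc3)sc2c1` gives 300 nM, and compound 3 `Cc1ccc(SCC(=O)Nc2ccc3nc(NC(=O)c4ccc(C(F)(F)F)cc4)sc3c2)c(C)c1` gives 320 nM. Among these three numbers compound 3 stands second highest: its nearest neighbour is compound 2, the two lying within the scatter of each other, while compound 1 is furthest away. Both steps out of compound 1 exchange the 1H-imidazol-2-yl on the sulfur for a carbon-only aromatic ring, with a 9.0-fold lower number from compound 1 to compound 2 (0.95 log units; beyond the scatter) and an 8.4-fold lower number from compound 1 to compound 3 (0.92 log units; beyond the scatter). The step between the two carbon-only rings, a 1.1-fold higher number from compound 2 to compound 3 (0.03 log units; within the scatter), stays within the scatter.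

Compound 4 `O=C(CSc1ccc(Cl)cc1)Nc1ccc2nc(NC(=O)c3ccc(C(F)(F)F)cc3)sc2c1` introduces the change (4-chlorophenyl in place of 2,4-dimethylphenyl on a sulfur). The step that bears most directly on it is the aryl-for-aryl exchange a 1.1-fold higher number from compound 2 to compound 3 (0.03 log units; within the scatter), which produced no movement beyond the scatter; the larger steps from compound 1 concern a different kind of ring and do not apply. Compound 4 is therefore expected to show a 1.1-fold higher number from compound 3 to compound 4 (0.04 log units; within the scatter), no shift beyond the scatter. Compound 4 is estimated at 350 nM, with a range from 150 nM to 900 nM.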

Compound 4, half-maximal inhibitory concentration: 930 nM
Beside the measured number, compound 4's estimate is 2.7-fold (0.42 log units) below it, and the stated range ends below it.
By their numbers in this assay, from the lowest: compounds 2 and 3 (each within the scatter of the next); then compound 4; then compound 1.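

Among the carbon-only aromatic rings on the sulfur, the choice of ring now makes a difference: compounds 2 and 3 lay within the scatter of each other, but 4-chlorophenyl in place of 2,4-dimethylphenyl gives a 2.9-fold higher number from compound 3 to compound 4 (0.46 log units; beyond the scatter) and 4-chlorophenyl in place of naphthalen-2-yl gives a 3.1-fold higher number from compound 2 to compound 4 (0.49 log units; beyond the scatter) on this sulfur. A carbon-only ring alone therefore does not fix the number, and compound 4 sits in the middle of the series, with a 2.9-fold lower number from compound 1 to compound 4 (0.46 log units; beyond the scatter) against the 1H-imidazol-2-yl ring. No measurement is available to account for this shift.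

The compounds shown leave open whether the chlorine or the loss of the two methyl groups drives the change, as both differ at once, and an unsubstituted phenyl or a 4-methylphenyl would separate them. Also open, going by these compounds, is how an amine or a carboxylic acid on this aryl ring would read.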